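Hydroxy for fluorophenylamino on the fused core

The source may report more compounds than this note shows. Statements on the series, on what has been measured and on what is new or still open speak of the compounds shown alone.

Measured so far:
compound 1 `Fc1cccc(Nc2nc3nonc3nc2Nc2ccccc2F)c1`: 190 nM
compound 2 `Oc1nc2nonc2nc1Nc1ccccc1F`: 12500 nM

In an assay on mitochondria from L6 cells (Rattus norvegicus) for activation, with a stated time of 90 min (on this read-out higher numbers stand for an effect only at larger amounts of compound and lower numbers for an effect already at smaller amounts), compound 1 gives 190 nM, the lowest of the two numbers. Compound 2 gives 12500 nM. Among the compounds with values here, the single measured step is a 66-fold higher number from compound 1 to compound 2 (1.82 log units; beyond the scatter), a large loss.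

Compound 3 `Oc1nc2nonc2nc1Nc1cccc(F)c1` is not yet measured. It differs from compound 1 by hydroxy in place of (2-fluorophenyl)amino on an aromatic carbon. The step from compound 1 to compound 2 is the closest guide, since there the same kind of exchange, hydroxy for a fluorophenylamino group, produced a large rise in the number. A comparable large rise, far beyond the scatter, is expected here. Compound 3 is estimated at 12000 nM, within 4000 nM to 40000 nM. This expectation corresponds to a 63-fold higher number from compound 1 to compound 3 (1.80 log units; beyond the scatter).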

Compound 3, half-maximal effective concentration: 31200 nM
For compound 3 the middle estimate is 2.6-fold (0.41 log units) below the measured one; measured number inside the range.
By their numbers in this assay, from the lowest: compound 1; then compound 2; then compound 3.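

With hydroxy in place of (2-fluorophenyl)amino, this assay shows a 160-fold higher number from compound 1 to compound 3 (2.22 log units; beyond the scatter), so the (3-fluorophenyl)amino group left on the shared core does not retain the low number of compound 1. The loss therefore appears with either fluorophenylamino group exchanged: compound 2 gives 12500 nM and compound 3 gives 31200 nM. Nothing at hand accounts for the size of this loss.

Still open, as far as these compounds go, is whether a plain amine or a methoxy group at this place would behave like hydroxy. An unsubstituted phenylamino group there also remains untested in the compounds shown.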